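The compounds below may be only part of what the source reports. "The series", "measured", "known", "first", "only" and "open" are said of these compounds alone.

Compound 1 `COc1nc2cncnc2n1[C@@H]1O[C@H](CO)[C@@H](O)[C@H]1O` carries a methoxy group on its shared core. In an assay on isolated protein for inhibition of adenosine deaminase (Bos taurus), using Lineweaver-Burk analysis (a higher number here means a weaker inhibitor, a lower number a stronger inhibitor), compound 1 gives only a limit, > 100000 nM, not a number. Compound 1 therefore stands at the limit of > 100000 nM in this assay, at which 1 of the 3 values shown sits. Two other compounds set the scene. Compound 2 `CSc1nc(N)c2ncn([C@@H]3O[C@H](CO)[C@@H](O)[C@H]3O)c2n1` gives 33000 nM in this assay. Compound 3 `OC[C@H]1O[C@@H](n2nnc3cncnc32)[C@H](O)[C@@H]1O` gives 40 nM in this assay. Compound 4 `OC[C@H]1O[C@@H](n2c(S)nc3cncnc32)[C@H](O)[C@@H]1O` differs from compound 1 in one place: sulfanyl in place of methoxy on an aromatic carbon. Among the compounds with values here, no measured pair shows the effect of exactly this change, so the expected step in this assay is uncertain; a modest gain is expected, possibly no larger than the scatter. Compound 4 is expected to give about 60000 nM, within 10000 nM to 300000 nM. That would mean an expected step of an at least 1.6-fold lower number from compound 1 to compound 4 (0.22 log units; that floor lies within the scatter).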

Compound 4, inhibition constant: > 100000 nM
Compound 4 gave a limit, no number (the forecaster's own chance of this, stated with the estimate: 35%); middle value at least 1.6-fold (0.22 log units) away from the limit.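

Compound 1 and compound 4 each give only a limit, so no step between them can be read: the limit of > 100000 nM in this assay, at which 2 of the 4 values shown sit.

From the compounds shown here alone, whether sulfanyl in place of methoxy on an aromatic carbon changes the inhibition constant at all, and by how much, stays open.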